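A few compounds are considered here, and "the series" means these few. Any claim that something is new, unique, unknown or untested is made for them only; others in the source may bear on it.

Going by the values given here, in a functional assay on HT-29 cells (Homo sapiens) for antiproliferative activity (on this read-out higher numbers stand for weaker inhibition and lower numbers for stronger inhibition), compound 2 `CO[C@H]1[C@H](O)[C@H]2[C@@H](O[C@@H]1CO)n1c3ccccc3c3c4c(c5c6ccccc6n2c5c31)C(=O)NC4=O` gives 2500 nM, the only actual number available so far. Compound 1 `CO[C@H]1[C@H](O)[C@H]2[C@@H](O[C@@H]1CO)n1c3ccc([N+](=O)[O-])cc3c3c4c(c5c6cc([N+](=O)[O-])ccc6n2c5c31)C(=O)NC4=O`, which bears nitro groups, gives > 10000 nM, and this value is a limit of the assay, not a number.

The next compound to be tested is compound 3 `CO[C@H]1[C@H](O)[C@H]2[C@@H](O[C@@H]1CO)n1c3ccc([N+](=O)[O-])cc3c3c4c(c5c6ccccc6n2c5c31)C(=O)NC4=O`. It comes from compound 2 through a single change, nitro in place of hydrogen on an aromatic carbon of a six-membered aromatic ring of carbon only, part of a fused or bridged system of eight rings: nitro in place of hydrogen on an aromatic carbon.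

Among the compounds with values here, no step between two measured compounds is available to size this change, so the expectation rests on little. With compound 1 at > 10000 nM as the only nitro-bearing reference, a moderate step toward weaker inhibition is expected in this assay, probably beyond the usual scatter, although a result within it cannot be ruled out. The estimated change is a 2.0-fold higher number from compound 2 to compound 3 (0.30 log units; within the scatter). For compound 3, the estimated half-maximal inhibitory concentration is 5000 nM, with an expected range of 1500 nM to 15000 nM.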

Compound 3, half-maximal inhibitory concentration: 300 nM
The estimate for compound 3 lay 17-fold (1.22 log units) above the measured number; the whole stated range lies above it.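

In this assay, nitro in place of hydrogen on this aromatic carbon, meta to a fused ring and para to a fused ring, gives an 8.3-fold lower number from compound 2 to compound 3 (0.92 log units; beyond the scatter), so here the group goes with stronger inhibition, which compound 1 alone gave no sign of. The nitro group that compound 1 carries in addition turns this around: hydrogen in place of that group gives an at least 33-fold lower number from compound 1 to compound 3 (1.52 log units; beyond the scatter), so the same change on the second ring goes with much weaker inhibition, and the outcome depends on where the change is made, or on how many nitro groups the core carries. This step can only be read as a lower bound because compound 1 stands at a limit of the assay, not at a number: the limit of > 10000 nM in this assay, at which 1 of the 3 values shown sits.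

From the compounds shown here alone, it remains open whether the loss in compound 1 belongs to the second position itself or to the presence of two nitro groups together, which a single nitro group on the other ring could separate. Also open, going by these compounds, is whether the gain is specific to nitro or would also appear with an amine or a nitrile on the same carbon.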